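Cyano for hydrogen on the phenoxyacetic acid core

The compounds below may be only part of what the source reports. "The series", "measured", "known", "first", "only" and "open" are said of these compounds alone.

Measured compounds in an assay on CHO cells for displacement of a labelled ligand from prostaglandin D2 receptor 2 (Homo sapiens), read by scintillation counting; on this read-out lower numbers stand for stronger inhibition and higher numbers for weaker inhibition:
compound 1 `O=C(O)COc1cc(F)ccc1C#Cc1ccccc1Cl`, 4780 nM
compound 2 `Cc1ncccc1C#Cc1cc(Cl)ccc1OCC(=O)O`, 143 nM
compound 3 `O=C(O)COc1ccccc1C#Cc1ccccc1Cl`, 747 nM

Compound 3 stands second highest of the three numbers, with compound 2 below it and compound 1 above it. Compound 4 `N#Cc1ccc(OCC(=O)O)c(C#Cc2ccccc2Cl)c1` differs from compound 3 by cyano in place of hydrogen on an aromatic carbon. For the measured compounds named here, the only single-place step recorded, a 6.4-fold lower number from compound 1 to compound 3 (0.81 log units; beyond the scatter), concerns a different substituent at another site and so bears only loosely here. Compound 2 carries both a chloro on the core ring and a different aryl group, so its gap to compound 3 cannot be assigned to one change. A small gain is expected for compound 4, a 1.9-fold lower number from compound 3 to compound 4 (0.27 log units; within the scatter) in this assay, giving an estimate of 400 nM with a range from 150 nM to 1500 nM.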

Compound 4, inhibition constant: 24 nM
Estimate against measurement, compound 4: 17-fold (1.22 log units) above; the whole stated range lies above it.
By their numbers in this assay, from the lowest: compound 4; then compound 2; then compound 3; then compound 1.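

In this assay, a 31-fold lower number from compound 3 to compound 4 (1.49 log units; beyond the scatter) shows that the position para to the carboxymethoxy group accepts a substituent and that cyano there gives a large gain. For the compounds shown here, the only earlier single-place step, a 6.4-fold lower number from compound 1 to compound 3 (0.81 log units; beyond the scatter), showed only that a fluoro at another site goes with a higher number. No measurement at hand accounts for the size of this new step.

From the compounds shown here alone, it remains open whether a carboxamide or a trifluoromethyl group at this position would match cyano. Also open, going by these compounds, is whether the gain carries over to the aryl group of compound 2.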